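Two Chlorines Replace a Fluorine on the Pendant Phenyl

The source may hold more compounds than are shown below. What is called first, only, known or untested is meant among the compounds shown, and "the series" means these compounds.

The compounds here share one core and differ only in the aromatic ring hung from a double-bonded chain carbon. Compound 3 `C=CCn1c(=O)/c(=C\c2ccccc2F)[nH]c(=O)/c1=C\c1ccccc1OC` carries a 2-fluorophenyl there; in a functional assay on K562 cells (Homo sapiens) for cytotoxicity, read by CCK-8 assay, with a stated time of 72 h (a higher number here means a weaker inhibitor, a lower number a stronger inhibitor), compound 3 gives 5600 nM, the highest of the three numbers measured. Compound 1 `C=CCn1c(=O)/c(=C\c2cccc(F)c2)[nH]c(=O)/c1=C\c1ccccc1OC` gives 4100 nM and compound 2 `C=CCn1c(=O)/c(=C\c2cccc(Br)c2)[nH]c(=O)/c1=C\c1ccccc1OC` gives 2400 nM.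

Compound 4 `C=CCn1c(=O)/c(=C\c2cccc(Cl)c2Cl)[nH]c(=O)/c1=C\c1ccccc1OC` is not yet measured. Its difference from compound 3 is 2,3-dichlorophenyl in place of 2-fluorophenyl on a double-bonded chain carbon bound to an aromatic carbon.

Among the compounds with values here, two measured steps bear on this. Moving the single fluorine to a 3-fluorophenyl gave a 1.4-fold higher number from compound 1 to compound 3 (0.14 log units; within the scatter) read backwards, and swapping bromo for fluoro gave a 1.7-fold lower number from compound 1 to compound 2 (0.23 log units; within the scatter). Within the data shown here, the one step beyond the scatter is a 2.3-fold higher number from compound 2 to compound 3 (0.37 log units; beyond the scatter), which again favours a 3-substituted ring over a 2-substituted one. Compound 4 keeps a substituent at the 2-position and adds one at the 3-position, so a modest fall in the number is expected, on the order of a 2.2-fold lower number from compound 3 to compound 4 (0.35 log units; beyond the scatter).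

Compound 4 is therefore estimated at 2500 nM in this assay, with a likely range from 1200 nM to 5500 nM.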

Compound 4, half-maximal inhibitory concentration: 900 nM
Compound 4: the middle estimate sits 2.8-fold (0.44 log units) above what was measured; measured number below the stated range.
By their numbers in this assay, from the lowest: compound 4; then compounds 2, 1 and 3 (each within the scatter of the next, the first and the last beyond it).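

In this assay, the aromatic ring on a double-bonded chain carbon proves able to move the number further than the single-halogen rings showed: 2,3-dichlorophenyl in place of 2-fluorophenyl gives a 6.2-fold lower number from compound 3 to compound 4 (0.79 log units; beyond the scatter), the largest step seen so far in this set. The same ring also outdoes the two rings named 3-fluorophenyl and 3-bromophenyl, with a 4.6-fold lower number from compound 1 to compound 4 (0.66 log units; beyond the scatter) and a 2.7-fold lower number from compound 2 to compound 4 (0.43 log units; beyond the scatter), so compound 4 is the strongest of the four, and its steps to all three others lie beyond the scatter. Nothing measured here explains why this change has such a large step.

This single change swaps the halogen and also adds a second one, so the compounds shown cannot separate the effect of chlorine from the effect of having two substituents, a question that rings such as 2-chlorophenyl and 3-chlorophenyl would address. As far as these compounds go, it also remains open whether halogens are needed at all, since a phenyl ring carrying an amine or a carboxylic acid at this place would test a very different kind of group.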